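A few compounds are considered here, and "the series" means these few. Any claim that something is new, unique, unknown or untested is made for them only; others in the source may bear on it.

Compound 1 `CCCCSc1nc(N)nc2c1ncn2/C=C1/CC1(CO)CO` reaches only the limit of an ADME assay on HFF cells (Homo sapiens) for cytotoxicity, with a stated time of 8 days (on this read-out lower numbers stand for higher toxicity in this test and higher numbers for lower toxicity in this test), reported as > 300000 nM. Compound 2 `CCCCCOc1nc(N)nc2c1ncn2/C=C1/CC1(CO)CO` gives 259000 nM in this assay. Compound 3 `Nc1nc2c(ncn2/C=C2/CC2(CO)CO)c(=O)[nH]1` likewise stops at the limit in this assay, > 300000 nM.

Among the measured compounds shown here, compound 2 thus holds the only actual number among the three; the other two values are limits, as the limit of > 300000 nM in this assay, at which 2 of the 3 values shown sit, records. For the measured compounds named here, the single step between measured compounds, an at least 1.1-fold lower number from compound 1 to compound 2 (0.06 log units; that floor lies within the scatter), is small, and its floor lies within the scatter.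

Compound 4 `COCCOc1nc(N)nc2c1ncn2/C=C1/CC1(CO)CO` differs from compound 2 in one place: methoxy in place of propyl on a saturated chain carbon, two bonds along the chain from an oxygen on an aromatic ring. Going by the values given here, no measured step touches this part of the chain; the only step available, an at least 1.1-fold lower number from compound 1 to compound 2 (0.06 log units; that floor lies within the scatter), concerns a group on an aromatic carbon and was itself small. For this assay a change beyond the scatter is therefore not expected in either direction. The expected step, a 1.1-fold higher number from compound 2 to compound 4 (0.03 log units; within the scatter), is small. Compound 4 is estimated at 280000 nM, with a range from 150000 nM to 600000 nM.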

Compound 4, half-maximal cytotoxic concentration: > 300000 nM
Compound 4: only a limit was reported; the forecaster's own chance of this, stated with the estimate: 50%; middle value at least 1.0-fold (0.02 log units) away from the limit.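

In this assay, replacing the propyl end of the pentyloxy chain with methoxy, which swaps a carbon-only end for one carrying a hydrogen-bond acceptor, gives an at least 1.1-fold higher number from compound 2 to compound 4 (0.06 log units; that floor lies within the scatter). So this chain position, unlike the aromatic carbon changed in the earlier step, has now been tested directly, and the change does not bring the number down, although the floor of the step cannot be told apart from the scatter. Compound 4 gives > 300000 nM, which is a limit, and the step from compound 1 to compound 4 cannot be read, since compound 2 now holds the only actual number: the limit of > 300000 nM in this assay, at which 3 of the 4 values shown sit.

From the compounds shown here alone, how far compound 4 really lies from compound 2 stays open. So does whether an amine or a carboxylic acid at the end of this chain, or a longer chain such as 2-ethoxyethoxy, would give a lower number in this assay.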